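Swapping an Amide for an Ester on the Shared Core

This account rests on a few compounds, and the source may have more. Where it says the series, first, only, none or still open, it means among the compounds named here.

Compound 1 `Cc1nc2c(OCc3ccccc3)cccn2c1C(N)=O` is the point of departure. In a functional assay on the whole organism with Rattus norvegicus as the target, with a stated time of 4 h, at a dose of 40 mg/kg by the intraperitoneal route (on this read-out lower numbers stand for less inhibition and higher numbers for more inhibition at the one dose given (going by the name of the read-out)), compound 1 gives 42%, the second highest of three results: compound 2 `CC(=O)c1c(C)nc2c(OCc3ccccc3)cccn12` gives 57%, while compound 3 `Cc1nc2c(OCc3ccccc3)cccn2c1Br` gives 26%. The change to compound 4 `CCCCC(=O)OCc1c(C)nc2c(OCc3ccccc3)cccn12` is ((butylcarbonyl)oxy)methyl in place of carbamoyl on an aromatic carbon. Among the compounds with values here, two measured steps bear on it. Keeping the carbonyl and putting methyl in place of amino gave a number 15 percentage points higher from compound 1 to compound 2 (beyond the scatter); removing the carbamoyl altogether for bromo gave a number 16 percentage points lower from compound 1 to compound 3 (beyond the scatter). Compound 4 keeps a carbonyl but loses the hydrogen-bond donor and carries a larger group, so only a small step, in either direction, is expected. Compound 4 is therefore estimated at 45%, within a range from 20% to 70%, which is expected to mean a number 3 percentage points higher from compound 1 to compound 4 (within the scatter).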

Compound 4, a percentage reported as inhibition, in the whole organism at one dose (the size of the read-out at that dose, not a potency): 45%
For compound 4 middle estimate and measured number coincide at the digits printed; the measured number falls inside the stated range.
By their numbers in this assay, from the lowest: compound 3; then compounds 1 and 4 (each within the scatter of the next); then compound 2.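

On this aromatic carbon, ((butylcarbonyl)oxy)methyl can take the place of carbamoyl in this assay without a shift beyond the scatter, giving a number 3 percentage points higher from compound 1 to compound 4 (within the scatter), even though the hydrogen-bond donor is gone and the group is larger. The same group compares with bromo as a number 19 percentage points higher from compound 3 to compound 4 (beyond the scatter) and with acetyl as a number 12 percentage points lower from compound 2 to compound 4 (beyond the scatter), so the largest of these groups does not give the highest number. Nothing measured here explains this order. Still open, on these data alone, is how a hydroxymethyl group, a carboxylic acid or a shorter ester chain on this carbon would compare.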